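Attachment point of the five-membered ring: compound 3 to compound 4

A few compounds are considered here, and "the series" means these few. Any claim that something is new, unique, unknown or untested is made for them only; others in the source may bear on it.

Compound 3 `CCC(C)(C)Cc1c[nH]c(CCc2ccc(-c3cnsc3)cc2)n1` gives 10 nM in an in vitro assay on CHO cells for displacement of a labelled ligand from Bombesin receptor subtype-3 (Homo sapiens), read by scintillation counting, with a stated time of 2 h (a lower number here means a stronger inhibitor, a higher number a weaker inhibitor), the second highest of three numbers; compound 2 `CCC(C)(C)Cc1c[nH]c(CCc2ccc(-c3cccnc3)cc2)n1` with 7.5 nM sits within the scatter, while compound 1 `CCC(C)(C)Cc1c[nH]c(CCc2ccc(-c3ccncc3)cc2)n1` with 101 nM lies a step beyond it, a 10-fold lower number from compound 1 to compound 3 (1.00 log units; beyond the scatter). Compound 4 `CCC(C)(C)Cc1c[nH]c(CCc2ccc(-c3ccns3)cc2)n1` differs from compound 3 only in 1,2-thiazol-5-yl in place of 1,2-thiazol-4-yl on an aromatic carbon. For the measured compounds named here, the steps that bear on this are those that moved the attachment of the six-membered heteroaromatic ring, a 13-fold lower number from compound 1 to compound 2 (1.13 log units; beyond the scatter) and a 10-fold lower number from compound 1 to compound 3 (1.00 log units; beyond the scatter), both beyond the scatter, and a 1.3-fold higher number from compound 2 to compound 3 (0.12 log units; within the scatter). Going by the values given here, a step of similar size is therefore possible in either direction, with no measured pair fixing the sign. Compound 4 is estimated at 30 nM, range 6 nM to 150 nM, an expected step of a 3.0-fold higher number from compound 3 to compound 4 (0.48 log units; beyond the scatter).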

Compound 4, half-maximal inhibitory concentration: 11 nM
Estimate against measurement, compound 4: 2.7-fold (0.44 log units) above; measured number inside the range.
By their numbers in this assay, from the lowest: compounds 2, 3 and 4 (each within the scatter of the next); then compound 1.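

Moving the attachment from 1,2-thiazol-4-yl to 1,2-thiazol-5-yl changes nothing beyond the scatter (a 1.1-fold higher number from compound 3 to compound 4 (0.04 log units; within the scatter)), whereas the one pyridine move shown was large (a 13-fold lower number from compound 1 to compound 2 (1.13 log units; beyond the scatter)). Compound 4 also stays level with the pyridin-3-yl compound (a 1.5-fold higher number from compound 2 to compound 4 (0.17 log units; within the scatter)) and keeps the gap to the pyridin-4-yl compound (a 9.2-fold lower number from compound 1 to compound 4 (0.96 log units; beyond the scatter)), so among these four compounds only compound 1 stands apart.

No evidence accounts for the pyridine difference or for the tolerance of both thiazole attachments. Open, from the compounds shown here alone, is whether a methyl group or an amine on the 1,2-thiazole ring, or a pyrimidine in its place, would hold this level.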